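Swapping a spirocycle for trifluoromethyl on the shared core

This account rests on a few compounds, and the source may have more. Where it says the series, first, only, none or still open, it means among the compounds named here.

Compound 3 `CN1CC2(CCN(c3ccc(OCc4ccccc4)c(C(=O)Nc4ccnnc4)c3)CC2)C1` stands lowest of the three measured compounds in a physicochemical assay for lipophilicity, at pH 7.4; on this read-out lower numbers stand for lower lipophilicity and higher numbers for higher lipophilicity: compound 3 gives 2.2, against compound 2 `O=C(Nc1ccnnc1)c1cc(N2CCC(O)CC2)ccc1OCc1ccccc1` at 3.2 and compound 1 `O=C(Nc1ccnnc1)c1cc(N2CCC(F)CC2)ccc1OCc1ccccc1` at 5.1. The two measured steps leading to compound 3 both point downward and are beyond the scatter: a number 2.90 log units lower from compound 1 to compound 3 (beyond the scatter) and a number 1.00 log units lower from compound 2 to compound 3 (beyond the scatter). The remaining measured step, a number 1.90 log units lower from compound 1 to compound 2 (beyond the scatter), is likewise large and downward.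

Compound 4 `O=C(Nc1ccnnc1)c1cc(C(F)(F)F)ccc1OCc1ccccc1` departs from compound 3 by a single change: a group of 4 heavy atoms (1 carbon, 3 fluorine; no ring) in place of a group of 10 heavy atoms (8 carbon, 2 nitrogen; one four-membered non-aromatic ring with 1 hetero atom, one six-membered non-aromatic ring with 1 hetero atom), on an aromatic carbon. Among the measured compounds shown here, no measured step exchanges the group of 10 heavy atoms for a trifluoromethyl group, so the direction can only be read indirectly. In both measured steps that end at compound 3, the group of 10 heavy atoms entered on an aromatic carbon in place of a smaller group, and in both the read-out fell by a large margin, as a number 2.90 log units lower from compound 1 to compound 3 (beyond the scatter) and a number 1.00 log units lower from compound 2 to compound 3 (beyond the scatter) show. Read in the reverse sense, taking that group off again in favour of a smaller ring-free group on an aromatic carbon is expected to move the read-out upward. On that basis a large upward step is expected, a number 2.30 log units higher from compound 3 to compound 4 (beyond the scatter), placing compound 4 between compound 2 and compound 1 rather than beyond either.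

The value of compound 4 in this assay is therefore estimated at 4.5, within a range from 3.8 to 5.2.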

Compound 4, distribution coefficient: 5.4
Estimate against measurement, compound 4: 0.90 log units below; measured number outside the range, above it.
By their numbers in this assay, from the lowest: compound 3; then compound 2; then compounds 1 and 4 (each within the scatter of the next).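

In this assay, the step from the spirocyclic group to trifluoromethyl on this aromatic carbon spans the full range seen so far: a number 3.20 log units higher from compound 3 to compound 4 (beyond the scatter). The exchange of 4-hydroxypiperidin-1-yl for trifluoromethyl is also large, a number 2.20 log units higher from compound 2 to compound 4 (beyond the scatter), but the exchange of 4-fluoropiperidin-1-yl for trifluoromethyl gives a number 0.30 log units higher from compound 1 to compound 4 (within the scatter), which shows that a group with no ring can match the ring-bearing group of compound 1 at this position. Nothing shown here accounts for the size of these steps or for the match between compound 1 and compound 4.

The compounds shown leave open where other small ring-free groups at this position would fall, such as a nitrile, a primary amine or a carboxylic acid, since trifluoromethyl is the only such group here. They also leave open whether an open-chain dimethylamino group or a simple unsubstituted piperidin-1-yl would sit closer to compound 3 or to compound 4, which would help separate the effect of the ring from that of its substituents.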